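The source may hold more compounds than are shown below. What is called first, only, known or untested is meant among the compounds shown, and "the series" means these compounds.

Working notes on the series. Compound 1 `Cc1cc(C)cc(Cn2c(=O)cc(NC3CCCCC3)n(Cc3ccccc3)c2=O)c1` is measured in an ADME assay on MT4 cells (Homo sapiens) for cytotoxicity, read by MTT assay, with a stated time of 4 days (on this read-out lower numbers stand for higher toxicity in this test and higher numbers for lower toxicity in this test), where compound 1 gives 74000 nM. Compound 2 `Cc1cc(C)cc(Cn2c(=O)cc(N=[N+]=[N-])n(CC#N)c2=O)c1` gives 60000 nM in this assay, and compound 3 `Cc1cc(C)cc(Cn2c(=O)cc(N(C)C)n(Cc3ccccc3)c2=O)c1` gives 48000 nM. Compound 1 shows the highest of the three numbers, but its gap to compound 2 and its gap to compound 3 both fall within the scatter, so no order can be read among the three. For the measured compounds named here, the one single-point step available is a 1.5-fold lower number from compound 1 to compound 3 (0.19 log units; within the scatter), a replacement of the group on the aromatic nitrogen of the shared core.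

Compound 4 `CC(=O)Nc1cc(=O)n(Cc2cc(C)cc(C)c2)c(=O)n1Cc1ccccc1` differs from compound 1 in that (acetyl in place of cyclohexyl on a nitrogen on an aromatic ring). Going by the values given here, the only measured step that bears on this site is a 1.5-fold lower number from compound 1 to compound 3 (0.19 log units; within the scatter), and it lay within the scatter; no measured pair shows what an acetyl does at this nitrogen. Since the one replacement measured at this nitrogen left this assay unchanged, compound 4 is expected to show a 1.1-fold lower number from compound 1 to compound 4 (0.02 log units; within the scatter), none beyond the scatter. The estimate for compound 4 in this assay is 70000 nM, in a range from 30000 nM to 160000 nM.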

Compound 4, half-maximal cytotoxic concentration: > 100000 nM
Compound 4: no number, only a limit (the forecaster's own chance of this, stated with the estimate: 25%); at least 1.4-fold (0.15 log units) between middle value and limit.
By their numbers in this assay, from the lowest: compounds 3, 2 and 1 (each within the scatter of the next). At a limit, above all of these: compound 4.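

In this assay compound 4 gives a limit of the assay and not a number: the limit of > 100000 nM in this assay, at which 1 of the 4 values shown sits. For the compounds shown here, this yields the first step that lies beyond the scatter, an at least 2.0-fold higher number from compound 3 to compound 4 (0.31 log units; beyond the scatter), with acetamido in place of dimethylamino on an aromatic carbon, so the group at this position can move the read-out, here towards lower toxicity in this test, and the true size of the step may be larger than this floor. Compound 1 gives a weaker reading, since the step with acetyl in place of cyclohexyl on a nitrogen on an aromatic ring is an at least 1.3-fold higher number from compound 1 to compound 4 (0.13 log units; that floor lies within the scatter), and that floor lies within the scatter, so this change is not shown to separate the two compounds.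

As far as these compounds go, the position of compound 4 beyond its limit stays open, so the full size of both steps remains unknown. Also open, from the compounds shown here alone, is whether a longer acyl chain, a carboxylic acid or a primary amine at this place would read as acetamido does, or whether the result holds for acetyl alone.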